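From pyridin-2-yl to 1,3-thiazol-2-yl on a shared core

The source may hold more compounds than are shown below. What is called first, only, known or untested is meant among the compounds shown, and "the series" means these compounds.

Three compounds have been measured so far in a functional assay on A549 cells (Homo sapiens) for cytotoxicity, read by MTT assay, with a stated time of 68 h (on this read-out higher numbers stand for weaker inhibition and lower numbers for stronger inhibition), and their results are:
- Compound 1 `Cc1ccccc1-c1cccc(NC(=O)C(Cl)Cl)c1` gives 9860 nM
- Compound 2 `O=C(Nc1cccc(-c2ccccn2)c1)C(Cl)Cl` gives > 50000 nM as a limit, not a number
- Compound 3 `Cc1ccc(-c2cccc(NC(=O)C(Cl)Cl)c2)cc1` gives 8300 nM

Compound 2 stands at the limit of > 50000 nM in this assay, at which 1 of the 3 values shown sits, and this is a limit, not a number. Compound 1 at 9860 nM and compound 3 at 8300 nM show that this assay can return numbers for close relatives.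

Compound 4 `O=C(Nc1cccc(-c2nccs2)c1)C(Cl)Cl` has not yet been measured. It carries 1,3-thiazol-2-yl in place of pyridin-2-yl on an aromatic carbon (in counts, (1,3-thiazol-2-yl in place of pyridin-2-yl on an aromatic carbon)).

Going by the values given here, no measured pair shows this swap directly. Compound 2 is the closest measured relative, at > 50000 nM as a limit, so compound 4 is expected to give weak inhibition too. The estimated step of an at least 1.6-fold lower number from compound 2 to compound 4 (0.22 log units; that floor lies within the scatter) in this assay is expected to be modest, toward stronger inhibition if there is any change. The estimate for compound 4 is 30000 nM with an expected range from 10000 nM to 60000 nM in this read-out.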

Compound 4, half-maximal inhibitory concentration: > 50000 nM
Compound 4: no number, only a limit; the forecaster's own chance of this, stated with the estimate: 40%; at least 1.6-fold (0.22 log units) between middle value and limit.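

Compound 2 and compound 4 each give a limit rather than a number in this assay, and the step between them cannot be read: the limit of > 50000 nM in this assay, at which 2 of the 4 values shown sit.

The compounds shown leave open whether 1,3-thiazol-2-yl in place of pyridin-2-yl changes inhibition at all, and by how much.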